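The source may report more compounds than this note shows. Statements on the series, on what has been measured and on what is new or still open speak of the compounds shown alone.

Series notes. Compound 1 `CC1CCN(C(=S)SCc2ccc(C(=O)Nc3ccccc3N)cc2)CC1` gives 72.5% in a functional assay on HeLa cells (Homo sapiens) for antiproliferative activity, read by CCK-8 assay, with a stated time of 72 h, tested at 8 uM; on this read-out lower numbers stand for a weaker effect and higher numbers for a stronger effect at the one concentration tested; compound 2 `CN(Cc1ccncc1)C(=S)SCc1ccc(C(=O)Nc2ccccc2N)cc1` gives 72.7% in this assay; compound 3 `Nc1ccccc1NC(=O)c1ccc(CSC(=S)N2CCc3cc(Cl)ccc32)cc1` gives 65.1% in this assay. On these numbers compound 3 is not set apart: a number 7.4 percentage points lower from compound 1 to compound 3 (within the scatter) and a number 7.6 percentage points lower from compound 2 to compound 3 (within the scatter) both stay within the scatter, as does a number 0.2 percentage points higher from compound 1 to compound 2 (within the scatter). Compound 4 `CN(C(=S)SCc1ccc(C(=O)Nc2ccccc2N)cc1)c1cccnc1` differs from compound 3 by methyl(pyridin-3-yl)amino in place of 5-chloro-2,3-dihydro-1H-indol-1-yl on a thiocarbonyl carbon. The measured steps that bear on an exchange at this thiocarbonyl carbon are the three above, and none reaches beyond the scatter, so no step beyond the scatter is expected in this assay here either. Compound 4 is therefore estimated at 70%, between 58% and 80%. The expected step is a number 4.9 percentage points higher from compound 3 to compound 4 (within the scatter).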

Compound 4, a percentage reported as inhibition, at one concentration (the size of the read-out at that concentration, not a potency): 70.5%
Beside the measured number, compound 4's estimate is 0.5 percentage points below it; measured number inside the range.
By their numbers in this assay, from the lowest: compounds 3, 4, 1 and 2 (each within the scatter of the next).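

In this assay, the steps of a number 5.4 percentage points higher from compound 3 to compound 4 (within the scatter) and a number 2 percentage points lower from compound 1 to compound 4 (within the scatter) show that methyl(pyridin-3-yl)amino on the thiocarbonyl carbon also leaves the read-out within the scatter, which extends the flat picture at this position to a fourth group. The step of a number 2.2 percentage points lower from compound 2 to compound 4 (within the scatter) adds a narrower exchange, pyridin-3-yl in place of (pyridin-4-yl)methyl on an amide-type nitrogen, and it too stays within the scatter. Nothing available bears on the reason for these results.

On these data alone, whether a carboxylic acid or a longer alkyl chain at the thiocarbonyl carbon would give a step beyond the scatter remains open. The single concentration also leaves potency differences among these compounds open.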